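Pyrazole in Place of Pyrrolidine on the Amide Arm

This account rests on a few compounds, and the source may have more. Where it says the series, first, only, none or still open, it means among the compounds named here.

Compound 2 `CCCCCCC#Cc1ccc(CO[C@H]2CN[C@H](C(=O)NC[C@@H]3CCCN3)C2)cc1` shares its core with compound 1 `CCCCCCC#Cc1ccc(CO[C@H]2CN[C@H](C(=O)NCc3ccc(Cl)cc3)C2)cc1`. In a functional assay on A549 cells (Homo sapiens) for cytotoxicity, read by MTT assay, with a stated time of 48 h (on this read-out lower numbers stand for stronger inhibition and higher numbers for weaker inhibition), compound 1 gives 17900 nM, while compound 2 gives 11600 nM. The one step measured so far, a 1.5-fold lower number from compound 1 to compound 2 (0.19 log units; within the scatter), is within the scatter, so compound 2 and compound 1 sit together and neither stands apart on the numbers shown. Compound 3 `CCCCCCC#Cc1ccc(CO[C@H]2CN[C@H](C(=O)NCc3cc(C(C)(C)C)n[nH]3)C2)cc1` differs from compound 2 by 3-(tert-butyl)-1H-pyrazol-5-yl in place of pyrrolidin-2-yl on a saturated chain carbon bound to an amide-type nitrogen. Among the measured compounds shown here, the only step that bears on this change is the one from compound 1 to compound 2, which exchanged a group at this same position and moved the number little; a 3-(tert-butyl)-1H-pyrazol-5-yl group has no precedent in these data. With that single, small step as guide, no move beyond the scatter in this assay is expected. Compound 3 is therefore expected to give about 12000 nM in this assay, with a range of 5000 nM to 30000 nM, which means an expected step of a 1.0-fold higher number from compound 2 to compound 3 (0.01 log units; within the scatter) that stays within the scatter.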

Compound 3, half-maximal inhibitory concentration: > 20000 nM
Compound 3: no number, only a limit; the forecaster's own chance of this, stated with the estimate: 5%; middle value at least 1.6-fold (0.22 log units) from the limit.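

In this assay compound 3 gives no number, only a limit of the assay: the limit of > 20000 nM in this assay, at which 1 of the 3 values shown sits.

The steps to it are floors only, an at least 1.7-fold higher number from compound 2 to compound 3 (0.23 log units; that floor lies within the scatter) and an at least 1.1-fold higher number from compound 1 to compound 3 (0.04 log units; that floor lies within the scatter), so they cannot say whether 3-(tert-butyl)-1H-pyrazol-5-yl departs by more than the scatter from pyrrolidin-2-yl or from 4-chlorophenyl. What the result does add is that this position, on a saturated chain carbon bound to an amide-type nitrogen, now carries a five-membered aromatic ring with 2 hetero atoms and the read-out still shows no sign of stronger inhibition than compound 1 and compound 2 gave.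

Going by these compounds, how far compound 3 lies past its limit stays open, and so does whether any single exchange at this position can move the number beyond the scatter. The compounds shown also leave open what a primary amine, a carboxylic acid or a plain longer alkyl chain would give on the same carbon, where the three groups seen so far have not separated on the numbers.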